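Compound 4 against the limit set by compound 3

This account rests on a few compounds, and the source may have more. Where it says the series, first, only, none or still open, it means among the compounds named here.

Compound 3 `Cc1cc(N2CCNCC2)nc(SCc2nc3ccccc3[nH]2)n1` stands in a functional assay on MCF7 cells (Homo sapiens) for cytotoxicity, read by MTT assay, with a stated time of 72 h (on this read-out lower numbers stand for stronger inhibition and higher numbers for weaker inhibition), only at a limit of the assay: compound 3 gives > 100000 nM. Two neighbours frame it. Compound 1 `COc1ccc(Nc2cc(C)nc(SCc3nc4ccccc4[nH]3)n2)cc1` gives 61100 nM in this assay. Compound 2 `Cc1cc(NCCO)nc(SCc2nc3ccccc3[nH]2)n1` is reported as a limit too, compound 2 giving > 100000 nM. The steps of an at least 1.6-fold higher number from compound 1 to compound 2 (0.21 log units; that floor lies within the scatter) and an at least 1.6-fold higher number from compound 1 to compound 3 (0.21 log units; that floor lies within the scatter) both run from a measured number into the limit, and a step that the two limits leave unreadable from compound 2 to compound 3 cannot be read at all, since the limit of > 100000 nM in this assay, at which 2 of the 3 values shown sit, holds both ends of that pair.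

Compound 4 `Cc1cc(NNC(N)=S)nc(SCc2nc3ccccc3[nH]2)n1` differs from compound 3 by a group of 5 heavy atoms (1 carbon, 3 nitrogen, 1 sulfur; no ring) in place of a group of 6 heavy atoms (4 carbon, 2 nitrogen; one six-membered non-aromatic ring with 2 hetero atoms), on an aromatic carbon. Within the data shown here, none of the measured steps exchanges a group of this kind, and the only one starting from compound 3 is unreadable, so no step size can be carried over. With compound 3 itself at a limit, the step of a number no higher from compound 3 to compound 4 (the limit leaves the size open) is expected to be small or not readable, and compound 4 is most likely to be reported again as a limit in this assay. The estimate for compound 4 is 100000 nM, with a range of 30000 nM to 300000 nM.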

Compound 4, half-maximal inhibitory concentration: > 100000 nM
Compound 4: no number, only a limit; the forecaster's own chance of this, stated with the estimate: 60%; the middle value sits exactly at the limit.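

At this aromatic carbon, an open-chain group holding sulfur now joins piperazin-1-yl and (2-hydroxyethyl)amino in giving no number in this assay, so a third, quite different substituent ends at the same limit: the limit of > 100000 nM in this assay, at which 3 of the 4 values shown sit.

The one readable step is an at least 1.6-fold higher number from compound 1 to compound 4 (0.21 log units; that floor lies within the scatter), so compound 4 is not shown to lie apart from compound 1 beyond the scatter. The steps among compound 2, compound 3 and compound 4 cannot be read, since both ends of each are limits.

Going by these compounds, how far these three compounds lie past the limit, and any order among them, stays open. Also open, on these data alone, is whether a 4-chlorophenylamino group or a longer alkyl amine at this carbon would give a measured number in this assay, as the (4-methoxyphenyl)amino group of compound 1 does with 61100 nM.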